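The compounds below may be only part of what the source reports. "The series", "measured", "known", "first", "only" and "open" are said of these compounds alone.

Three compounds have been measured in a functional assay on MV4-11 cells (Homo sapiens) for antiproliferative activity, read by CCK-8 assay, with a stated time of 72 h; a lower number here means a stronger inhibitor, a higher number a weaker inhibitor:

- Compound 1 `Cc1cc(F)cc(C)c1Oc1ccc(C(C)(C)O)cc1-c1cn(C)c(=O)c2[nH]c(C(=O)NCc3ccc(C(=O)NO)cc3)cc12` gives 440 nM
- Compound 2 `Cc1cc(F)cc(C)c1Oc1ccc(C(C)(C)O)cc1-c1cn(C)c(=O)c2[nH]c(C(=O)NCc3ccc(C(=O)Nc4ccccc4N)cc3)cc12` gives 240 nM
- Compound 3 `Cn1cc(-c2ccccc2)c2cc(C(=O)NCc3ccc(C(=O)Nc4ccccc4N)cc3)[nH]c2c1=O` gives 230 nM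

In this assay, compound 2 at 240 nM lies within the scatter of compound 3 at 230 nM and of compound 1 at 440 nM, so the three numbers give no clear ranking.

Compound 4 `Cn1cc(-c2cc(C(C)(C)O)ccc2Oc2ccccc2)c2cc(C(=O)NCc3ccc(C(=O)Nc4ccccc4N)cc3)[nH]c2c1=O` departs from compound 2 at a single place: phenyl in place of 4-fluoro-2,6-dimethylphenyl on an oxygen on an aromatic ring.

Going by the values given here, no measured step covers this exact change. The only one available, a 1.8-fold lower number from compound 1 to compound 2 (0.26 log units; within the scatter), swaps hydroxy for 2-aminophenyl on an amide-type nitrogen, elsewhere in the molecule, and compound 4 keeps the 2-aminophenyl group of compound 2. The closest evidence comes from compound 3, which has neither the 4-fluoro-2,6-dimethylphenoxy nor the phenoxy group and still gives 230 nM, level with compound 2 within the scatter. A step beyond the scatter is therefore not expected, though no direct measurement supports this.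

The estimated step is a 1.0-fold lower number from compound 2 to compound 4 (0.02 log units; within the scatter), which would stay within the scatter. For compound 4 the expected value is 230 nM, with an estimated range of 100 nM to 520 nM.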

Compound 4, half-maximal inhibitory concentration: 100 nM
For compound 4 the middle estimate is 2.3-fold (0.36 log units) above the measured one, and the stated range covers the measured number.
By their numbers in this assay, from the lowest: compound 4; then compounds 3, 2 and 1 (each within the scatter of the next).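

In this assay, going by these compounds alone, the change from 4-fluoro-2,6-dimethylphenoxy to phenoxy gives a 2.4-fold lower number from compound 2 to compound 4 (0.38 log units; beyond the scatter), so this is the first single change that moves the number beyond the scatter, though only modestly. The smaller phenyl group, with no fluorine or methyl groups, is thus at least compatible with stronger antiproliferative activity at this position on the oxygen, whereas the earlier change on the amide-type nitrogen, a 1.8-fold lower number from compound 1 to compound 2 (0.26 log units; within the scatter), stayed within the scatter. Nothing available explains the difference between the two groups on the oxygen.

Within the data shown here, the single step removes the fluorine and both methyl groups together, so it remains open whether 4-fluorophenyl or 2,6-dimethylphenyl on that oxygen would give a number closer to that of compound 2 or to that of compound 4, and what a saturated ring such as cyclohexyl would give there. As far as these compounds go, it also remains open whether the same step would hold with hydroxy in place of 2-aminophenyl on the amide-type nitrogen.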